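The source may report more compounds than this note shows. Statements on the series, on what has been measured and on what is new or still open speak of the compounds shown alone.

In a functional assay on A549 cells (Homo sapiens) for cytotoxicity, read by MTT assay, with a stated time of 72 h (a higher number here means a weaker inhibitor, a lower number a stronger inhibitor), compound 1 (`CCC[S+]([O-])CCCCN=C=S`) gives 10700 nM and compound 2 (`CC(C)[S+]([O-])CCCCN=C=S`) gives 10400 nM. For the measured compounds named here, compound 1 therefore stands level with the only other measured compound, the two lying within the scatter of each other. Compound 3 (`[O-][S+](CCCCN=C=S)Cc1ccco1`) has yet to be measured. It differs from compound 1 by furan-2-yl in place of ethyl on a saturated chain carbon bound to a sulfur, with furan-2-yl in place of ethyl on a saturated chain carbon bound to a sulfur. Going by the values given here, only one measured step bears on this change: a 1.0-fold lower number from compound 1 to compound 2 (0.01 log units; within the scatter), where isopropyl replaces propyl on a sulfur. That step stayed within the scatter, but no ring enters in it, so it is a weak guide here. No clear step is therefore expected in this assay, and the estimated change is a 1.2-fold lower number from compound 1 to compound 3 (0.08 log units; within the scatter). Compound 3 is estimated at 9000 nM, with an expected range of 4500 nM to 18000 nM.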

Compound 3, half-maximal inhibitory concentration: 5640 nM
Estimate against measurement, compound 3: 1.6-fold (0.20 log units) above; measured number inside the range.
By their numbers in this assay, from the lowest: compounds 3, 2 and 1 (each within the scatter of the next).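

In this assay, furan-2-yl in place of ethyl on a saturated chain carbon bound to a sulfur gives a 1.9-fold lower number from compound 1 to compound 3 (0.28 log units; within the scatter). The earlier step only rearranged a small open chain, whereas this one brings in a five-membered aromatic ring with a hydrogen-bond acceptor, and the number still does not move beyond the scatter, so this place accepts a larger, ring-bearing group without a clear change in this cell read-out. No measurement shown offers an explanation for this result.

A phenyl ring, with carbon atoms only, would show whether the ring oxygen of furan-2-yl matters at all. On these data alone, an amine or a carboxylic acid at this same place also remains open, as does whether any group here can produce a step beyond the scatter.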